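The source may hold more compounds than are shown below. What is called first, only, known or untested is meant among the compounds shown, and "the series" means these compounds.

Measured so far in a physicochemical assay for solubility, read by nephelometry, measured as kinetic solubility, at pH 2, tested at 10 mg/mL; on this read-out higher numbers stand for higher solubility and lower numbers for lower solubility:
compound 1 `CC(C)(CC(=O)Nc1ccc(F)c(C(F)(F)F)c1)C(=O)O` gives 25 ug/mL;
compound 2 `CC(C)(C(=O)O)n1c(=O)[nH]c2cc(C(F)(F)F)c(F)cc21` gives 50 ug/mL;
compound 3 `CC(C)(C(=O)O)N1Cc2cc(F)c(C(F)(F)F)cc2NC1=O` gives 50 ug/mL.

Compound 1 sits at the low end of these three numbers, yet compound 2 and compound 3 each lie within the usual scatter of it, so the three read as one level rather than a spread. Compound 4 `CC(C)(NC(=O)Nc1ccc(F)c(C(F)(F)F)c1)C(N)=O` is not yet measured. It differs from compound 1 by (1-carbamoyl-1-methylethyl)amino in place of 2-carboxy-2-methylpropyl on a carbonyl carbon. Among the measured compounds shown here, no step between measured compounds bears directly on this change, so nothing measured here points in either direction. Compound 4 is expected to give a number in this assay close to that of compound 1, with the step of no change at the digits printed from compound 1 to compound 4 (within the scatter) expected to stay within the scatter. The estimate for compound 4 is 25 ug/mL, with a range from 8 ug/mL to 80 ug/mL.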

Compound 4, solubility: 50 ug/mL
Compound 4: the middle estimate sits 2.0-fold (0.30 log units) below what was measured; the range from low to high includes it.
By their numbers in this assay, from the lowest: compounds 1, 2, 3 and 4 (each within the scatter of the next).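

In this assay the exchange of 2-carboxy-2-methylpropyl for (1-carbamoyl-1-methylethyl)amino on a carbonyl carbon gives the first step read at this position (a 2.0-fold higher number from compound 1 to compound 4 (0.30 log units; within the scatter)). The carboxylic acid of compound 1 can therefore be replaced here by this carbamoyl-bearing group with the number staying within the scatter. No available evidence accounts for this outcome.

Still open, going by these compounds, is whether a simple amine or a longer alkyl chain at this place would stay at the same level. One step also cannot show whether the result carries over to other cores.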